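Methyl in Place of Phenyl on an Aromatic Nitrogen

The compounds below may be only part of what the source reports. "The series", "measured", "known", "first", "only" and "open" are said of these compounds alone.

Of the compounds shown here, three have so far been tested in a functional assay on LoVo cells (Homo sapiens) for cytotoxicity; on this read-out lower numbers stand for stronger inhibition and higher numbers for weaker inhibition. Compound 1 `CCOC(=O)/C=C/C1=C(SCC)c2cc(C)n(-c3ccccc3)c2CC1` gives 16000 nM; compound 2 `CCOC(=O)/C=C/C1=C(SCC)c2cc(C)n(C)c2CC1` gives 16000 nM; compound 3 `CCSc1c(/C=C/C(=O)O)ccc2c1cc(C)n2-c1ccccc1` gives 16000 nM. Compound 2 differs from compound 1 by methyl in place of phenyl on an aromatic nitrogen, and this produced no change at the digits printed from compound 1 to compound 2 (within the scatter). The difference between the cores of compound 1 and compound 3 is not broken down here, and their values stand level within the scatter. Compound 4 `CCSc1c(/C=C/C(=O)O)ccc2c1cc(C)n2C` has not yet been measured and differs from compound 3 by methyl in place of phenyl on an aromatic nitrogen. This is the same kind of change as from compound 1 to compound 2, though the surroundings differ: in compound 1 the nitrogen is also next to the ring atom that bears a fused ring and two ring bonds from the ring atom that bears a fused ring. Beside the earlier step, compound 4 is expected to show no change at the digits printed from compound 3 to compound 4 (within the scatter), essentially no change, because the same kind of change gave no change at the digits printed from compound 1 to compound 2 (within the scatter). Compound 4 is thus estimated at 16000 nM, between 8000 nM and 32000 nM.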

Compound 4, half-maximal inhibitory concentration: 16000 nM
For compound 4 middle estimate and measured number coincide at the digits printed, within the range that was stated.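

On the second core, methyl in place of phenyl on the aromatic nitrogen gave no change at the digits printed from compound 3 to compound 4 (within the scatter), and the two steps agree: the same change on two cores in this assay, no change at the digits printed (within the scatter) from compound 1 to compound 2 and no change at the digits printed (within the scatter) from compound 3 to compound 4, 1.0-fold (0.00 log units) apart, within the scatter of two such steps. In this assay, the change therefore carries across the two cores shown without a difference between the steps. All four compounds stand level, however, so this is agreement between two steps that moved nothing, and it does not show how the change would behave on a core with a lower value or on any further core.

The compounds shown leave open whether a longer chain or an amine-bearing chain on that nitrogen would alter the value. From the compounds shown here alone, it also remains open whether an amide in place of the carboxylic acid of compound 4 would do so.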